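Fluoro at the Outer Ring in Two Related Series

The source may hold more compounds than are shown below. What is called first, only, known or untested is meant among the compounds shown, and "the series" means these compounds.

Measured so far, all in a functional assay on A2780 cells (Homo sapiens) for inhibition, read by sulforhodamine B assay; on this read-out higher numbers stand for weaker inhibition of growth and lower numbers for stronger inhibition of growth:
compound 1, `Oc1cccc2[nH]c(-c3ccc(-c4ccc(-c5ccccc5)cc4)cc3)nc12`: 41000 nM
compound 2, `Oc1cccc2[nH]c(-c3ccc(-c4ccc(-c5ccc(F)cc5)cc4)cc3)nc12`: 41200 nM
compound 3, `Cc1ccc2[nH]c(-c3ccc(-c4ccc(-c5ccccc5)cc4)cc3)nc2c1`: 41200 nM

Compound 2 differs from compound 1 by fluoro in place of hydrogen on an aromatic carbon, and in this assay that change gave a 1.0-fold higher number from compound 1 to compound 2 (0.00 log units; within the scatter). Compound 3 carries a different core than compound 1; the difference between the two cores is not broken down here. Compound 4, `Cc1ccc2[nH]c(-c3ccc(-c4ccc(-c5ccc(F)cc5)cc4)cc3)nc2c1`, has not yet been measured. Among the measured compounds shown here, it differs from compound 3 by fluoro in place of hydrogen on an aromatic carbon, the same change as the one made from compound 1 to compound 2, at the same place on the outer ring. Because the earlier change gave a 1.0-fold higher number from compound 1 to compound 2 (0.00 log units; within the scatter), the same change on the core of compound 3 is expected to give a 1.0-fold lower number from compound 3 to compound 4 (0.00 log units; within the scatter). On that basis compound 4 is estimated at 41000 nM in this assay, most likely between 20000 nM and 85000 nM.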

Compound 4, concentration for 50% growth inhibition: 24600 nM
The estimate for compound 4 lay 1.7-fold (0.22 log units) above the measured number, and the stated range covers the measured number.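

In this assay, replacing phenyl with 4-fluorophenyl on the second core gave a 1.7-fold lower number from compound 3 to compound 4 (0.22 log units; within the scatter). Set beside the earlier step, the two results do not differ by more than the scatter: the same change on two cores in this assay, a 1.0-fold higher number (0.00 log units; within the scatter) from compound 1 to compound 2 and a 1.7-fold lower number (0.22 log units; within the scatter) from compound 3 to compound 4, 1.7-fold (0.23 log units) apart, within the scatter of two such steps. This shows that the change behaves alike on these two cores, with neither step beyond the scatter, but it does not show that fluoro improves growth inhibition on either core or that the same would hold on any other core.

The compounds shown leave open whether a different group at the same place on the outer ring, such as an amine or a carboxylic acid, would give a step beyond the scatter. They also leave open whether a larger group, such as a longer chain, would carry from one core to the other in the same way.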